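A few compounds are considered here, and "the series" means these few. Any claim that something is new, unique, unknown or untested is made for them only; others in the source may bear on it.

Measured compounds:
- compound 1 `CC(C)(C)OC(=O)N1CCC(CNC(=O)c2ccccc2C2CCN(CCN3C(=O)COc4ccccc43)CC2)CC1`: 430 nM in an assay on RMS13 cells for displacement of a labelled ligand from Urotensin-2 receptor (Homo sapiens), with a stated time of 2.5 h; a higher number here means a weaker inhibitor, a lower number a stronger inhibitor
- compound 2 `O=C(NCC1CCN(S(=O)(=O)Cc2ccccc2)CC1)c1cc(Cl)ccc1C1CCN(CCN2C(=O)COc3ccccc32)CC1`: 30 nM in this assay

Of the two numbers shown, compound 2 has the lowest; the nearest is compound 1, whose number is higher by a margin that lies beyond the usual scatter, so compound 2 stands as the stronger inhibitor of the pair in this assay. Compound 3 `CC(C)(C)CC(=O)N1CCC(CNC(=O)c2cc(Cl)ccc2C2CCN(CCN3C(=O)COc4ccccc43)CC2)CC1` has not yet been measured. It differs from compound 2 in one place: neopentylcarbonyl in place of benzylsulfonyl on an amine nitrogen in a ring. Within the data shown here, compound 1 also carries a non-aromatic group on that ring nitrogen and lacks the chlorine of compound 2; in this assay compound 1 gives 430 nM, but no single-change step connects compound 1 to either of the others, so that pair only shows what its two values show. With the benzylsulfonyl of compound 2 gone, a weaker result is expected for compound 3, and the step from compound 2 to compound 3 is estimated at a 3.7-fold higher number from compound 2 to compound 3 (0.56 log units; beyond the scatter), likely beyond the scatter. Compound 3 is therefore expected to give about 110 nM in this assay, within a range of 35 nM to 400 nM.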

Compound 3, inhibition constant: 27 nM
The estimate for compound 3 lay 4.1-fold (0.61 log units) above the measured number; measured number outside the range, below it.
By their numbers in this assay, from the lowest: compounds 3 and 2 (each within the scatter of the next); then compound 1.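

At this amine nitrogen in a ring, neopentylcarbonyl in place of benzylsulfonyl amounts in this assay to a 1.1-fold lower number from compound 2 to compound 3 (0.05 log units; within the scatter), so the two groups cannot be told apart here. Among these compounds, this is the first direct evidence at this position: one group with a six-membered aromatic ring of carbon only and one with no ring give matching results, and compound 3, at 27 nM, shows that the aromatic ring of benzylsulfonyl is not required to reach this level. The same pair shows that a carbonyl-linked group can match a sulfonyl-linked one, although nothing available explains why these two different groups give such similar values.

The compounds shown leave open whether this tolerance extends to an unsubstituted ring nitrogen, a small acetyl group, a basic amine or a carboxylic acid at this position. Among the compounds shown here, they also leave the contribution of the chlorine unresolved, since compound 1, at 430 nM, differs from compound 2 and compound 3 in more than one place and no pair isolates that atom.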